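Methyl on the chain carbon of compound 3

A few compounds are considered here, and "the series" means these few. Any claim that something is new, unique, unknown or untested is made for them only; others in the source may bear on it.

Working notes on three compounds sharing one core, read in an ADME assay on MT4 cells (Homo sapiens) for cytotoxicity, read by MTT assay; on this read-out lower numbers stand for higher toxicity in this test and higher numbers for lower toxicity in this test. Among the compounds with values here, compound 1 `Cc1cc(C)cc(S(=O)(=O)c2c(C(=O)NCC(=O)NC(C)c3ccccc3)[nH]c3ccc(Cl)cc23)c1` gives 29400 nM, the only actual number so far. Compound 2 `Cc1cc(C)cc(S(=O)(=O)c2c(C(=O)NC(C)c3ccco3)[nH]c3ccc(Cl)cc23)c1` gives > 54700 nM, which is a limit of the assay. Compound 3 `Cc1cc(C)cc(S(=O)(=O)c2c(C(=O)NCC(=O)NCc3ccncn3)[nH]c3ccc(Cl)cc23)c1` gives > 48800 nM, which is also a limit.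

Compound 4 `Cc1cc(C)cc(S(=O)(=O)c2c(C(=O)NC(C)C(=O)NCc3ccncn3)[nH]c3ccc(Cl)cc23)c1` follows from compound 3 through methyl in place of hydrogen on a saturated chain carbon bound to an amide-type nitrogen and a carbonyl carbon.

Within the data shown here, no measured step makes this exact change. The nearest evidence is an at least 1.6-fold higher number from compound 1 to compound 3 (0.22 log units; that floor lies within the scatter), together with an at least 1.8-fold higher number from compound 1 to compound 2 (0.26 log units; that floor lies within the scatter). Both are floors, so neither fixes a true size, and a step that the two limits leave unreadable from compound 2 to compound 3 adds no size at all. No step beyond the scatter is therefore expected in this assay, and no direction can be assigned. The expected step is a step that the limit leaves unreadable from compound 3 to compound 4. For compound 4 the estimated value is 50000 nM, with an expected range of 22000 nM to 100000 nM.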

Compound 4, half-maximal cytotoxic concentration: 28100 nM
Compound 4: middle estimate off by 1.8-fold (0.25 log units), on the high side; the range from low to high includes it.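

In this assay, within the data shown here, methyl in place of hydrogen on this saturated chain carbon gives an at least 1.7-fold lower number from compound 3 to compound 4 (0.23 log units; that floor lies within the scatter), the first step at this position, and it replaces a limit with an actual number for a compound carrying the (pyrimidin-4-yl)methyl group. The comparison with the furan-2-yl compound gives an at least 1.9-fold lower number from compound 2 to compound 4 (0.28 log units; that floor lies within the scatter), which is also only a floor. Compound 4 and the 1-phenylethyl compound cannot be told apart in this assay, with a 1.0-fold lower number from compound 1 to compound 4 (0.02 log units; within the scatter), although their groups on the amide-type nitrogen differ.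

From the compounds shown here alone, whether the methyl truly shifts the number stays open because compound 3 is held at a limit: the limit of > 48800 nM in this assay, at which 1 of the 4 values shown sits. How an ethyl group or a carboxylic acid on the same chain carbon would read in this assay also remains open.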